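The source may report more compounds than this note shows. Statements on the series, on what has been measured and on what is new or still open speak of the compounds shown alone.

Measured so far in a functional assay on PC-3 cells (Homo sapiens) for inhibition, read by MTT assay, with a stated time of 72 h; a lower number here means a stronger inhibitor, a higher number a weaker inhibitor:
compound 1 `O=C(CSc1nc(Nc2ccccc2)c2ccccc2n1)Nc1cccc(Br)c1`: 11400 nM
compound 2 `O=C(CSc1nc(Nc2ccccc2)c2ccccc2n1)Nc1ccc(Cl)cc1Cl`: 9110 nM
compound 3 `C=CC(=O)Nc1cccc(NC(=O)CSc2nc(Nc3ccccc3C)c3ccccc3n2)c1`: 23200 nM

Among these three, compound 3 gives the highest number in this assay; compound 1 is nearest to it, and compound 2, the lowest of the three, is furthest, both gaps lying beyond the scatter. The unmeasured compound 4 `C=CC(=O)Nc1cccc(NC(=O)CSc2nc(Nc3ccc(Br)cc3)c3ccccc3n2)c1` differs from compound 3 only in the aryl group on the ring-bound amino nitrogen: 4-bromophenyl in place of 2-methylphenyl on a nitrogen on an aromatic ring. Put another way, (2-methylphenyl)amino becomes (4-bromophenyl)amino, while the acrylamide-bearing side of the molecule is kept as it is.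

Among the compounds with values here, only one measured step exists, a 1.3-fold lower number from compound 1 to compound 2 (0.10 log units; within the scatter), and it concerns a different place, the amide-type nitrogen, where 2,4-dichlorophenyl replaced 3-bromophenyl. That step stayed within the scatter, and nothing measured here touches the aryl group on the ring nitrogen. There is therefore no basis for expecting a large shift in either direction; the most reasonable expectation for compound 4 is a number close to that of compound 3, with the change a 1.2-fold lower number from compound 3 to compound 4 (0.06 log units; within the scatter) expected to fall within the scatter. Compound 4 is accordingly estimated at 20000 nM, with a range from 8000 nM to 50000 nM.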

Compound 4, half-maximal inhibitory concentration: 12400 nM
Compound 4: the middle estimate sits 1.6-fold (0.21 log units) above what was measured, within the range that was stated.
By their numbers in this assay, from the lowest: compounds 2, 1, 4 and 3 (each within the scatter of the next, the first and the last beyond it).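

In this assay, within the data shown here, the aryl group on the ring-bound amino nitrogen is varied for the first time, and the change from 2-methylphenyl to 4-bromophenyl on this nitrogen gives a 1.9-fold lower number from compound 3 to compound 4 (0.27 log units; within the scatter) with the acrylamide-bearing side of the molecule held constant. This place therefore tolerates an exchange of methyl for bromine, together with a change in where that substituent is named on the phenyl ring, without a shift beyond the scatter, a result that the earlier step on the amide-type nitrogen could not provide. No supporting measurement accompanies this result, so the data offer no explanation for it.

Because the substituent and its named ring position change together in this one step, the compounds shown do not separate the two, and 4-methylphenyl or 2-bromophenyl on the same nitrogen would be needed to do so. From the compounds shown here alone, it also remains open whether this place would respond more strongly to a group of a different kind, such as a phenyl ring carrying a carboxylic acid or a dimethylamino group, or a cyclohexyl ring in place of the phenyl ring.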